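From nitro to methyl: estimating compound 3

This account rests on a few compounds, and the source may have more. Where it says the series, first, only, none or still open, it means among the compounds named here.

Compound 1 `O=C(/C=C/c1c[nH]c2ccccc12)c1ccncc1`: 49300 nM
Compound 2 `O=C(/C=C/c1cn(S(=O)(=O)c2ccc([N+](=O)[O-])cc2)c2ccccc12)c1ccncc1`: 18300 nM

In a functional assay on HepG2 cells (Homo sapiens) for antiproliferative activity, read by MTT assay, with a stated time of 48 h (on this read-out lower numbers stand for stronger inhibition and higher numbers for weaker inhibition), compound 2 gives 18300 nM, the lower of the two numbers, and compound 1 gives 49300 nM. That gap lies beyond the usual scatter. Compound 3 `Cc1ccc(S(=O)(=O)n2cc(/C=C/C(=O)c3ccncc3)c3ccccc32)cc1` is still unmeasured. It differs from compound 2 by having methyl in place of nitro on an aromatic carbon. Among the compounds with values here, no measured pair shows this change, so the expectation is uncertain. The expected step in this assay, a 1.3-fold higher number from compound 2 to compound 3 (0.12 log units; within the scatter), is small and towards a higher number. For compound 3 the estimated value is 24000 nM, with an expected range of 10000 nM to 50000 nM.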

Compound 3, half-maximal inhibitory concentration: 44800 nM
Compound 3: the middle estimate sits 1.9-fold (0.27 log units) below what was measured; the range from low to high includes it.
By their numbers in this assay, from the lowest: compound 2; then compounds 3 and 1 (each within the scatter of the next).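

In this assay, replacing nitro with methyl on the aromatic ring gives a 2.4-fold higher number from compound 2 to compound 3 (0.39 log units; beyond the scatter). Within the data shown here, this shows that the group at this place on the ring can shift the number beyond the scatter, which the earlier compounds could not show because they offered no change at this position. Nothing available here explains this step.

This single pair cannot tell whether nitro is favourable or methyl unfavourable. An amine or a chlorine atom at the same place on the same core would test how the number follows the group there.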